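Swapping 4-fluorophenyl for thiophen-2-yl

The source may report more compounds than this note shows. Statements on the series, on what has been measured and on what is new or still open speak of the compounds shown alone.

Going by the values given here, in a functional assay on U-937 cells (Homo sapiens) for inhibition, read by MTT assay, with a stated time of 72 h (a lower number here means a stronger inhibitor, a higher number a weaker inhibitor), compound 1 (`O=C(NO)c1ccc(CNCc2nc(-c3ccc(Cl)cc3)no2)cc1`) gives 5290 nM and compound 2 (`O=C(NO)c1ccc(CNCc2nc(-c3ccc(F)cc3)no2)cc1`) gives 2950 nM as the only numbers so far. Among the compounds with values here, the one measured step, fluoro in place of chloro on an aromatic carbon, is a 1.8-fold lower number from compound 1 to compound 2 (0.25 log units; within the scatter) and so leaves compound 2 indistinguishable from compound 1. Compound 3 (`O=C(NO)c1ccc(CNCc2nc(-c3cccs3)no2)cc1`) departs from compound 2 in a larger way (thiophen-2-yl in place of 4-fluorophenyl on an aromatic carbon) with thiophen-2-yl in place of 4-fluorophenyl on an aromatic carbon. Within the data shown here, no measured compound carries thiophen-2-yl, and the step of a 1.8-fold lower number from compound 1 to compound 2 (0.25 log units; within the scatter) exchanges a single atom on the ring rather than the ring itself, so it is only a weak guide. The data give no direction, and no shift beyond the scatter is expected in this assay for this change. The estimated step is a 1.2-fold higher number from compound 2 to compound 3 (0.07 log units; within the scatter) and stays within the scatter. Compound 3 is estimated at 3500 nM with an expected range from 1400 nM to 8000 nM in this measurement.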

Compound 3, half-maximal inhibitory concentration: 10700 nM
Compound 3: middle estimate off by 3.1-fold (0.49 log units), on the low side; measured number above the stated range.
By their numbers in this assay, from the lowest: compounds 2 and 1 (each within the scatter of the next); then compound 3.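

At this aromatic carbon of the five-membered ring, between two ring nitrogen atoms, the exchange of one halogen on the phenyl group had not separated compound 1 from compound 2 in this assay. Replacing the whole phenyl group with thiophen-2-yl does produce a separation, with a 3.6-fold higher number from compound 2 to compound 3 (0.56 log units; beyond the scatter) and a 2.0-fold higher number from compound 1 to compound 3 (0.31 log units; beyond the scatter), both modest and beyond the scatter. Among these three compounds, the position therefore tolerates the change of halogen but responds to the change of ring, and compound 3 is the weakest inhibitor. Nothing available explains this rise.

The compounds shown do not separate the contributions of ring size, the ring sulfur and the loss of the halogen. On these data alone, it also stays open whether an unsubstituted phenyl, a furan-2-yl or a 5-chlorothiophen-2-yl group at this carbon would match the halogenated phenyl compounds or compound 3.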